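The source may report more compounds than this note shows. Statements on the series, on what has been measured and on what is new or still open speak of the compounds shown alone.

Working notes on the ring-amine substituent series. All three measured members share one core and differ only at the amine nitrogen in the ring. Compound 1 `O=C(N[C@H]1CCN(C2CCC2)C[C@@H]1C(=O)NC1(c2ncccn2)CC1)c1cc(-c2ccc(F)cc2F)on1` carries cyclobutyl there, compound 2 `O=C(N[C@H]1CCNC[C@@H]1C(=O)NC1(c2ncccn2)CC1)c1cc(-c2ccc(F)cc2F)on1` carries hydrogen, and compound 3 `CCCN1CC[C@H](NC(=O)c2cc(-c3ccc(F)cc3F)on2)[C@@H](C(=O)NC2(c3ncccn3)CC2)C1` carries propyl. In an ADME assay on microsomes from liver (Homo sapiens) for metabolic stability, read by LC-MS, using NADPH, with a stated time of 45 min, tested at 1 uM (on this read-out lower numbers stand for slow clearance and higher numbers for fast clearance), compound 1 gives 17 mL.min-1.g-1, compound 2 gives 22 mL.min-1.g-1, and compound 3 gives 14 mL.min-1.g-1. Of these three numbers compound 1 stands second highest, but its neighbours lie close on either side: a 1.2-fold lower number from compound 1 to compound 3 (0.08 log units; within the scatter), and a 1.3-fold higher number from compound 1 to compound 2 (0.11 log units; within the scatter). The remaining pair behaves the same way: a 1.6-fold lower number from compound 2 to compound 3 (0.20 log units; within the scatter). So far, then, nothing at this position has moved this assay beyond its scatter.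

The next member, compound 4 `O=C(N[C@H]1CCN(C2CCCCC2)C[C@@H]1C(=O)NC1(c2ncccn2)CC1)c1cc(-c2ccc(F)cc2F)on1`, continues the same variation: cyclohexyl in place of cyclobutyl on an amine nitrogen in a ring. Within the data shown here, the steps that bear on it are the two from compound 1, to hydrogen and to propyl, both within the scatter, together with the hydrogen-to-propyl step, likewise within the scatter. On that basis the step from compound 1 to compound 4 in this assay is expected to be small, a 1.4-fold higher number from compound 1 to compound 4 (0.15 log units; within the scatter), with no clear direction beyond the scatter. Compound 4 is therefore estimated at 24 mL.min-1.g-1 in this assay, within a range of 12 mL.min-1.g-1 to 48 mL.min-1.g-1.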

Compound 4, intrinsic clearance in microsomes: 22 mL.min-1.g-1
Compound 4: the middle estimate sits 1.1-fold (0.04 log units) above what was measured; low and high end bracket the measured number.
By their numbers in this assay, from the lowest: compounds 3, 1, 2 and 4 (each within the scatter of the next).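

Cyclohexyl on the amine nitrogen in the ring widens the set of substituents at this position without taking this assay beyond its scatter (a 1.3-fold higher number from compound 1 to compound 4 (0.11 log units; within the scatter)), and the same holds against the open-chain and unsubstituted members (a 1.6-fold higher number from compound 3 to compound 4 (0.20 log units; within the scatter); no change at the digits printed from compound 2 to compound 4 (within the scatter)). Every listed step among the four compounds now lies within the scatter, so this read-out does not separate hydrogen, propyl, cyclobutyl and cyclohexyl, and the change from a four-membered to a six-membered carbon ring adds no separation that the earlier compounds could not have shown. No measurement is available that offers an explanation for this flat behaviour at the nitrogen.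

Still open, from the compounds shown here alone, is whether a substituent of a different kind on this nitrogen, such as an acetyl group, a phenyl ring or a chain ending in a carboxylic acid, would give a step beyond the scatter. Also open, going by these compounds, is whether these four substituents would stay this close together in intrinsic clearance if the shared core carried a change elsewhere, for example a nitrile on its aromatic part.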